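This account rests on a few compounds, and the source may have more. Where it says the series, first, only, none or still open, it means among the compounds named here.

For the measured compounds named here, in a functional assay on A549 cells (Homo sapiens) for antiproliferative activity, read by MTT assay, with a stated time of 72 h (a lower number here means a stronger inhibitor, a higher number a weaker inhibitor), three compounds sharing one core have numbers so far. Compound 1 `COc1ccc(/C=C/C(=O)/C=C/c2nc(C)c(C)nc2C)cc1` gives 3500 nM, and compound 2 `COc1ccc(/C=C/C(=O)/C=C/c2nc(C)c(C)nc2C)c(OC)c1` gives 3070 nM, so these two cannot be told apart. Compound 3 `COc1cc(/C=C/C(=O)/C=C/c2nc(C)c(C)nc2C)cc(OC)c1OC` gives 1600 nM, a number lower than that of compound 1 by more than the usual scatter. Compound 1 therefore sits at the high end of these numbers, with compound 2 within the scatter of it.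

Compound 4 `Cc1ccc(/C=C/C(=O)/C=C/c2nc(C)c(C)nc2C)cc1` differs from compound 1 in one place: methyl in place of methoxy on an aromatic carbon, para to a large group (methyl in place of methoxy on an aromatic carbon). Going by the values given here, no measured step makes this exact swap. Among the compounds with values here, the only measured single-place step, a 1.1-fold lower number from compound 1 to compound 2 (0.06 log units; within the scatter), is a different change, methoxy in place of hydrogen on an aromatic carbon, and it is small. Within the data shown here, with that step as the only and rather loose guide, no shift beyond the scatter is expected in this assay, in either direction. The expected step is a 1.1-fold lower number from compound 1 to compound 4 (0.03 log units; within the scatter). For compound 4 the estimated value is 3300 nM, with an expected range from 1500 nM to 7000 nM.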

Compound 4, half-maximal inhibitory concentration: 4300 nM
Compound 4: middle estimate off by 1.3-fold (0.11 log units), on the low side; low and high end bracket the measured number.
By their numbers in this assay, from the lowest: compounds 3, 2, 1 and 4 (each within the scatter of the next, the first and the last beyond it).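

In this assay, putting methyl in place of methoxy on the aromatic carbon para to a large group gives a 1.2-fold higher number from compound 1 to compound 4 (0.09 log units; within the scatter), so the two groups cannot be told apart here. The earlier single-place step added a methoxy in place of hydrogen and left this methoxy untouched, whereas this step shows that it can give way to a methyl, with one heavy atom fewer and no hydrogen-bond acceptor, without a shift this assay can resolve. Nothing given here explains why the number holds, so this remains an observation about the two groups and nothing more.

On these data alone, only methoxy and methyl have been compared at this position, and both are small, so it stays open whether an amine, a carboxylic acid or a longer chain such as butoxy would move the number beyond the scatter. As far as these compounds go, it is also open whether a bare hydrogen there would do the same, and whether the swap would behave alike on compound 2 or compound 3, which carry further methoxy groups on the same ring.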